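Ethoxycarbonyl in Place of Acetyl on a Shared Core

The compounds below may be only part of what the source reports. "The series", "measured", "known", "first", "only" and "open" are said of these compounds alone.

compound 1 `O=C(CCCCC1CCSS1)NCc1cn(CCCOc2ccc3ccc(=O)oc3c2)nn1`: 37.2%
compound 2 `Cc1cc(=O)oc2cc(OCCCn3cc(CNC(=O)CCCCC4CCSS4)nn3)ccc12`: 54.5%
compound 3 `CC(=O)c1cc2ccc(OCCCn3cc(CNC(=O)CCCCC4CCSS4)nn3)cc2oc1=O`: 35.5%

Of the compounds shown here, three sharing one core have been tested in a functional assay on PC-12 cells (Rattus norvegicus) for cytotoxicity, read by MTT assay, with stated times of 3 h and 2 h, tested at 1 uM; on this read-out higher numbers stand for a stronger effect at the one concentration tested and lower numbers for a weaker effect. Compound 1 gives 37.2%, compound 2 gives 54.5%, and compound 3 gives 35.5%. Compound 3 holds the lowest of the three numbers; compound 1 sits nearest to it, within the scatter, while compound 2 lies furthest away, beyond the scatter. The two measured steps are a number 17.3 percentage points higher from compound 1 to compound 2 (beyond the scatter) and a number 1.7 percentage points lower from compound 1 to compound 3 (within the scatter).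

Compound 4 `CCOC(=O)c1cc2ccc(OCCCn3cc(CNC(=O)CCCCC4CCSS4)nn3)cc2oc1=O` has not yet been measured. It differs from compound 3 in one place: ethoxy in place of methyl on a carbonyl carbon. The carbonyl carbon carrying the change has an aromatic carbon as its other neighbour. Neither measured step touches this carbonyl carbon; both alter a substituent on an aromatic carbon of the core. The step of a number 1.7 percentage points lower from compound 1 to compound 3 (within the scatter) shows that bringing the acetyl onto the core left the number within the scatter, so the group now being altered has so far had little visible effect in this assay. For the measured compounds named here, with no direct precedent, compound 4 is expected to show no step beyond the scatter, an expected a number 1.5 percentage points higher from compound 3 to compound 4 (within the scatter). Compound 4 is therefore estimated at 37%, with a range from 25% to 50%.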

Compound 4, a percentage reported as activity, at one concentration (the size of the read-out at that concentration, not a potency): 28.3%
Estimate against measurement, compound 4: 8.7 percentage points above, within the range that was stated.
By their numbers in this assay, from the lowest: compounds 4, 3 and 1 (each within the scatter of the next); then compound 2.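

On the carbonyl carbon whose other neighbour is an aromatic carbon, ethoxy in place of methyl adds heavy atoms and a hydrogen-bond acceptor, yet in this assay this change gives a number 7.2 percentage points lower from compound 3 to compound 4 (within the scatter) and so leaves the number within the usual spread of repeats. Compared with the hydrogen of the shared core, the whole ethoxycarbonyl group gives a number 8.9 percentage points lower from compound 1 to compound 4 (within the scatter) in this assay and, like the acetyl before it, produces no step beyond the scatter, so the only step from compound 1 that goes beyond the scatter remains a number 17.3 percentage points higher from compound 1 to compound 2 (beyond the scatter) for the methyl of compound 2. No measurement shown here explains why these two carbonyl groups read alike in this assay.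

Going by these compounds, whether a carboxylic acid or a primary amide on this carbonyl carbon, or an ester with a longer chain than ethoxy, would move the number beyond the scatter stays open. With one concentration per compound, the numbers also leave open how these compounds would compare across a range of concentrations.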